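Tolerated concentrations across the amide and urea analogues

The source may hold more compounds than are shown below. What is called first, only, known or untested is meant among the compounds shown, and "the series" means these compounds.

Compound 1, `O=C(Nc1cccc(-n2cc(-c3ccncc3)c(-c3ccc(Cl)c(O)c3)n2)c1)Nc1cccc(C(F)(F)F)c1`, in a functional assay on MOLT-4 cells (Homo sapiens) for inhibition, read by sulforhodamine B assay, with a stated time of 48 h (a higher number here means that more compound is tolerated, a lower number that less compound is tolerated), gives > 32500 nM, a limit of the assay.
Compound 2, `COc1cc(-c2nn(-c3cccc(NC(=O)c4cccc(C(F)(F)F)c4)c3)cc2-c2ccncc2)ccc1Cl`, gives > 50000 nM, again a limit.
Compound 3, `COc1cc(-c2nn(-c3cccc(NC(=O)Nc4ccc(Cl)c(Cl)c4)c3)cc2-c2ccncc2)ccc1Cl`, gives > 50000 nM, also a limit.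

Compound 3 thus stands at the limit of > 50000 nM in this assay, at which 2 of the 3 values shown sit; compound 1 sits at the limit of > 32500 nM in this assay, at which 1 of the 3 values shown sits. Within the data shown here, the only single-point step, a step that the two limits leave unreadable from compound 2 to compound 3, is unreadable. Compound 4, `O=C(Nc1cccc(-n2cc(-c3ccncc3)c(-c3ccc(Cl)c(O)c3)n2)c1)Nc1ccc(Cl)c(Cl)c1`, differs from compound 3 by hydrogen in place of methyl on an oxygen on an aromatic ring. Among the measured compounds shown here, no measured step covers this change; compound 1, which carries the hydroxy group with a different urea, is itself at a limit. Compound 4 is therefore expected to remain at a limit, estimated near 50000 nM within 25000 nM to 100000 nM. The step of a number no higher from compound 3 to compound 4 (the limit leaves the size open) is expected to lie within scatter.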

Compound 4, concentration lethal to 50% of the cells: > 32500 nM
Compound 4 gave a limit, no number; the forecaster's own chance of this, stated with the estimate: 85%; the middle value lies beyond the limit too.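

Among these compounds, compound 1, compound 3 and compound 4 all stand as limits, so no step among them can be read. In this assay the compounds shown leave open whether methoxy to hydroxy, or 3,4-dichlorophenyl in place of 3-(trifluoromethyl)phenyl, changes the tolerated concentration at all.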